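This account rests on a few compounds, and the source may have more. Where it says the series, first, only, none or still open, it means among the compounds named here.

Measured so far in a functional assay on A549 cells (Homo sapiens) for antiproliferative activity, read by MTT assay, with a stated time of 48 h; a lower number here means a stronger inhibitor, a higher number a weaker inhibitor:
- compound 1 `COc1ccc(N(C)c2ccnc(Cl)n2)cc1OCCCCBr` gives 591 nM
- compound 2 `COc1ccc(N(C)c2ccnc(Cl)n2)cc1OCC[Se]C#N` gives 463 nM
- compound 3 `COc1ccc(N(C)c2cc(C)nc(C)n2)cc1F` gives 632 nM

These three values lie within the usual scatter of one another, so compound 3 stands level with compound 1 and compound 2. The next structure is compound 4 `COc1ccc(N(C)c2cc(C)nc(C)n2)cc1[N+](=O)[O-]` and the change is nitro in place of fluoro on an aromatic carbon in which nitro replaces fluoro on an aromatic carbon, ortho to a methoxy group. Going by the values given here, the only measured step is a 1.3-fold lower number from compound 1 to compound 2 (0.11 log units; within the scatter) at a different place in the molecule, and no swap of fluoro for nitro has been measured. That gives no direction, so the expected change is a 1.1-fold lower number from compound 3 to compound 4 (0.06 log units; within the scatter) and no shift beyond the scatter is expected. For compound 4 the estimated value is 550 nM with an expected range of 170 nM to 1800 nM in this assay here.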

Compound 4, half-maximal inhibitory concentration: 3270 nM
For compound 4 the middle estimate is 5.9-fold (0.77 log units) below the measured one; measured number outside the range, above it.
By their numbers in this assay, from the lowest: compounds 2, 1 and 3 (each within the scatter of the next); then compound 4.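

Nitro in place of fluoro, on this aromatic carbon ortho to a methoxy group, gives the first step here that lies beyond the scatter: in this assay it is a 5.2-fold higher number from compound 3 to compound 4 (0.71 log units; beyond the scatter). So this position does not accept every group equally, and here nitro gives the weaker inhibitor. No measurement at hand accounts for this difference.

The compounds shown leave open how an amine or a carboxylic acid at this position would compare with fluoro and nitro. They also leave open whether this swap would give a similar step on another core.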